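Cyclopentyl to cyclohexyl on the saturated chain carbon

This account rests on a few compounds, and the source may have more. Where it says the series, first, only, none or still open, it means among the compounds named here.

Compound 1 `Nc1nc(CC2CCCC2)c(-c2ccccc2Br)n1CC(=O)Nc1ccccc1` serves as the reference of the set. In a functional assay on A-375 cells (Homo sapiens) for antiproliferative activity, read by MTT assay, with a stated time of 48 h (on this read-out lower numbers stand for stronger inhibition and higher numbers for weaker inhibition), compound 1 gives 24300 nM. Compound 2 `Nc1nc(CC2CCCCC2)c(-c2ccccc2Br)n1CC(=O)Nc1ccccc1` carries cyclohexyl in place of cyclopentyl on a saturated chain carbon bound to an aromatic carbon; in this assay compound 2 gives 40600 nM, a step of a 1.7-fold higher number from compound 1 to compound 2 (0.22 log units; within the scatter). Compound 3 `Cc1ccc(NC(=O)Cn2c(N)nc(CC3CCCC3)c2-c2ccccc2Br)cc1` differs from compound 1 in its core by methyl in place of hydrogen on an aromatic carbon, and in this assay compound 3 gives 47800 nM, a step of a 2.0-fold higher number from compound 1 to compound 3 (0.29 log units; within the scatter). Compound 3 has the highest of the three numbers, but compounds 1 and 2 both lie within the scatter of it, so no order among the three is drawn.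

Compound 4 `Cc1ccc(NC(=O)Cn2c(N)nc(CC3CCCCC3)c2-c2ccccc2Br)cc1` is not yet measured. It differs from compound 3 by cyclohexyl in place of cyclopentyl on a saturated chain carbon bound to an aromatic carbon, the same change as from compound 1 to compound 2, at the same place, so this change occurs twice in the set. On that single precedent the step from compound 3 to compound 4 in this assay is expected to be a 1.5-fold higher number from compound 3 to compound 4 (0.17 log units; within the scatter), because a 1.7-fold higher number from compound 1 to compound 2 (0.22 log units; within the scatter) stayed within the scatter. Compound 4 is estimated at 70000 nM in this assay, with an expected range from 30000 nM to 160000 nM.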

Compound 4, half-maximal inhibitory concentration: 17500 nM
Beside the measured number, compound 4's estimate is 4.0-fold (0.60 log units) above it; measured number below the stated range.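

In this assay, cyclohexyl in place of cyclopentyl on the methyl-bearing core gives a 2.7-fold lower number from compound 3 to compound 4 (0.44 log units; beyond the scatter), and this step does not match the one seen on the core of compound 1: the same change on two cores in this assay, a 1.7-fold higher number (0.22 log units; within the scatter) from compound 1 to compound 2 and a 2.7-fold lower number (0.44 log units; beyond the scatter) from compound 3 to compound 4, 4.6-fold (0.66 log units) apart, beyond the scatter of two such steps

The methyl change behaves in the same way, giving a 2.3-fold lower number from compound 2 to compound 4 (0.37 log units; beyond the scatter) on the cyclohexyl-bearing core, and this too does not match its earlier step: the same change on two cores in this assay, a 2.0-fold higher number (0.29 log units; within the scatter) from compound 1 to compound 3 and a 2.3-fold lower number (0.37 log units; beyond the scatter) from compound 2 to compound 4, 4.6-fold (0.66 log units) apart, beyond the scatter of two such steps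

In these compounds, therefore, neither change carries unaltered from one core to the other, and the two changes do not add up independently; this rests on a single closed set of four compounds and shows that the two places are coupled here, not why they are, nor whether the coupling extends beyond this set.

Open, going by these compounds, is whether the same coupling appears with cycloheptyl in place of cyclohexyl, or with a chlorine or a methoxy in place of the methyl on that aromatic carbon. Also open, on these data alone, is whether a longer chain between the saturated ring and the aromatic carbon keeps the gap between the steps.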